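A few compounds are considered here, and "the series" means these few. Any claim that something is new, unique, unknown or untested is made for them only; others in the source may bear on it.

Compound 1 `O=C(c1ccccc1)N1CCC(NS(=O)(=O)c2cc(S(=O)(=O)c3ccccc3)ccc2C(F)(F)F)CC1`: 250 nM in an assay on U2OS cells for inhibition of secreted frizzled-related protein 1 (Homo sapiens), read by a luciferase reporter, with a stated time of 18 h; on this read-out higher numbers stand for an effect only at larger amounts of compound and lower numbers for an effect already at smaller amounts
Compound 2 `O=C(c1ccccn1)N1CCC(NS(=O)(=O)c2cc(S(=O)(=O)c3ccccc3)ccc2C(F)(F)F)CC1`: 230 nM in this assay
Compound 3 `O=C(O)c1ccc(S(=O)(=O)N2CCC(NS(=O)(=O)c3cc(S(=O)(=O)c4ccccc4)ccc3C(F)(F)F)CC2)cc1`: 110 nM in this assay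

Of the three measured compounds, compound 3 gives the lowest number in this assay; its steps to the other two, a 2.3-fold lower number from compound 1 to compound 3 (0.36 log units; beyond the scatter) and a 2.1-fold lower number from compound 2 to compound 3 (0.32 log units; beyond the scatter), are both beyond the scatter, so on these numbers compound 3 stands as the strongest. The values of compound 1 and compound 2 lie within the scatter of each other, and no order between them is claimed.

Compound 4 `O=C(O)c1ccc(N2CCC(NS(=O)(=O)c3cc(S(=O)(=O)c4ccccc4)ccc3C(F)(F)F)CC2)cc1` differs from compound 3 in one place: 4-carboxyphenyl in place of (4-carboxyphenyl)sulfonyl on an amine nitrogen in a ring. Among the compounds with values here, none of the measured steps changes this linking atom; the two steps into compound 3 exchange the whole group on that ring nitrogen, and both were modest. Within the data shown here, compound 4 keeps the 4-carboxyphenyl ring of compound 3 and drops only the sulfonyl between it and the ring nitrogen, so no measured step bears directly on it. Because the steps of a 2.3-fold lower number from compound 1 to compound 3 (0.36 log units; beyond the scatter) and a 2.1-fold lower number from compound 2 to compound 3 (0.32 log units; beyond the scatter) were modest, a step of similar size in either direction, or none beyond the scatter, is expected; the estimated step is a 1.8-fold higher number from compound 3 to compound 4 (0.26 log units; within the scatter). Compound 4 is thus expected to give about 200 nM in this assay, with a range from 60 nM to 700 nM.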

Compound 4, half-maximal effective concentration: 230 nM
Compound 4: the middle estimate sits 1.2-fold (0.06 log units) below what was measured; the measured number falls inside the stated range.
By their numbers in this assay, from the lowest: compound 3; then compounds 2, 4 and 1 (each within the scatter of the next).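

In this assay, taking out only the sulfonyl and keeping the 4-carboxyphenyl ring on the amine nitrogen in the ring gives a step of its own (a 2.1-fold higher number from compound 3 to compound 4 (0.32 log units; beyond the scatter)), so the lowest number in the series goes with the sulfonyl link together with that ring and not with the ring alone. With the ring attached directly to that nitrogen, the result cannot be told apart from those of the two carbonyl-linked groups (no change at the digits printed from compound 2 to compound 4 (within the scatter); a 1.1-fold lower number from compound 1 to compound 4 (0.04 log units; within the scatter)), which shows that the 4-carboxyphenyl ring by itself brings nothing beyond the scatter over (pyridin-2-yl)carbonyl or benzoyl. No accompanying measurement bears on why the sulfonyl link makes this difference.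

The compounds shown leave open whether a carbonyl or a methylene link carrying the same 4-carboxyphenyl ring would behave like the sulfonyl or like the direct attachment. They also leave open what the carboxylic acid contributes, which a plain phenylsulfonyl group, or a primary amide or tetrazole in place of the acid, could test.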